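Removing the Fluoro Substituent: Working Notes on Compound 4

This account rests on a few compounds, and the source may have more. Where it says the series, first, only, none or still open, it means among the compounds named here.

Measured compounds:
compound 1 `Fc1ccc(-c2nc3ncccc3o2)cc1` gives 28%
compound 2 `Brc1ccccc1-c1nc2cccnc2o1` gives 31%
compound 3 `Fc1ccc(-c2nc3ncccc3o2)c(F)c1` gives 23%

In a functional assay on the whole organism for inhibition, with Rattus norvegicus as the target, at a dose of 30 mg/kg (on this read-out lower numbers stand for less inhibition and higher numbers for more inhibition at the one dose given (going by the name of the read-out)), the three measured compounds all lie within the usual scatter of one another. Compound 1 sits in the middle of the three numbers: compound 2 is nearest and compound 3 is furthest, both differences within the scatter. For the measured compounds named here, no compound can be called stronger or weaker than another on these data.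

Compound 4 `c1ccc(-c2nc3ncccc3o2)cc1` has not yet been measured. Relative to compound 1 the change is hydrogen in place of fluoro on an aromatic carbon.

Going by the values given here, only one measured step touches a fluoro group: a number 5 percentage points lower from compound 1 to compound 3 (within the scatter). That step put a fluoro on compound 1 at a different place and moved the number by less than the scatter. Nothing in the series shows a change at the place concerned here. Among the compounds with values here, since the one fluoro step seen was within the scatter, no step beyond the scatter is expected for compound 4 in this assay either.

The estimate for compound 4 is 28%, with a range from 15% to 41%, which corresponds to an expected step of no change at the digits printed from compound 1 to compound 4 (within the scatter).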

Compound 4, a percentage reported as inhibition, in the whole organism at one dose (the size of the read-out at that dose, not a potency): 41%
Compound 4: the middle estimate sits 13 percentage points below what was measured; low and high end bracket the measured number.
By their numbers in this assay, from the lowest: compounds 3, 1, 2 and 4 (each within the scatter of the next, the first and the last beyond it).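

In this assay, hydrogen in place of fluoro on the aromatic carbon para to a group of 9 heavy atoms gives a number 13 percentage points higher from compound 1 to compound 4 (beyond the scatter), so this place responds to the change, modestly, in a way the earlier fluoro step could not reveal: a number 5 percentage points lower from compound 1 to compound 3 (within the scatter) added a fluoro at a different place and left the number within the scatter. The series therefore no longer reads as flat, and the fluoro of compound 1 cannot be treated as interchangeable with hydrogen at this position, although the finding rests on this single pair. Nothing available explains why the number moves with this change.

The compounds shown leave open whether the step belongs to fluoro in particular or would appear with any group at this place, such as a methoxy group, an amine or a carboxylic acid. They also leave open whether the same exchange would give a similar step with the second fluoro of compound 3 in place, and whether it would hold at doses other than the one given.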